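The compounds below may be only part of what the source reports. "The series", "measured", "known", "first", "only" and "open" are said of these compounds alone.

Compound 1 `C=C1CC[C@@H]2[C@](C)(CO[Si](c3ccccc3)(c3ccccc3)C(C)(C)C)[C@H](OC(C)=O)CC[C@@]2(C)[C@@H]1C/C=C1/C(=O)OC[C@H]1O`: 9.86 uM
Compound 2 `C=C1CC[C@@H]2[C@](C)(CO[Si](C)(C)C(C)(C)C)[C@H](O)CC[C@@]2(C)[C@@H]1C/C=C1/C(=O)OC[C@H]1OC(C)=O`: 10.7 uM
Compound 3 `C=C1CC[C@@H]2[C@](C)(CO[Si](C)(C)C(C)(C)C)[C@H](O)CC[C@@]2(C)[C@@H]1C/C=C1/C(=O)OC[C@H]1O`: 40.7 uM

In a functional assay on KB cells (Homo sapiens) for cytotoxicity, read by sulforhodamine B assay (a lower number here means that less compound is needed, a higher number that more compound is needed for the effect), compound 3 stands highest of the three, with compound 2 giving a lower number and compound 1 a lower number still. Compound 4 `C=C1CC[C@@H]2[C@](C)(CO[Si](C(C)C)(C(C)C)C(C)C)[C@H](O)CC[C@@]2(C)[C@@H]1C/C=C1/C(=O)OC[C@H]1O` differs from compound 3 by a group of 10 heavy atoms (9 carbon, 1 silicon; no ring) in place of a group of 7 heavy atoms (6 carbon, 1 silicon; no ring), on an oxygen on a saturated carbon. Going by the values given here, the only single-place step among the measured compounds, a 3.8-fold higher number from compound 2 to compound 3 (0.58 log units; beyond the scatter), concerns the acetyl on a different oxygen and tells nothing about the group exchanged here. Compound 1 carries yet another group at that oxygen together with the acetyl elsewhere, so it offers no clean comparison. Among the compounds with values here, with no measured step bearing on this change, the expected step of a 1.2-fold lower number from compound 3 to compound 4 (0.07 log units; within the scatter) is none beyond the scatter. Compound 4 is therefore estimated at 35 uM, with a range from 12 uM to 100 uM.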

Compound 4, concentration for half-maximal effect: 2.73 uM
Compound 4: middle estimate off by 13-fold (1.11 log units), on the high side; the whole stated range lies above it.
By their numbers in this assay, from the lowest: compound 4; then compounds 1 and 2 (each within the scatter of the next); then compound 3.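

In this assay the exchange on this oxygen on a saturated carbon gives a 15-fold lower number from compound 3 to compound 4 (1.17 log units; beyond the scatter), so this position, which earlier offered no single-place comparison, clearly responds to the silicon group it carries. Both groups have no ring and no hydrogen-bond donors or acceptors, and they differ in heavy atom count, yet that count alone explains nothing here. No evidence available here accounts for the step. The compounds shown leave open whether silicon is needed at this oxygen at all. A free hydroxyl, a methyl ether or a benzyl ether there would test that.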